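From a Cyclobutyl Amide to an Oxane-Bearing Amide

A few compounds are considered here, and "the series" means these few. Any claim that something is new, unique, unknown or untested is made for them only; others in the source may bear on it.

In an assay on HEK293 cells for negative allosteric modulation of metabotropic glutamate receptor 5 (Homo sapiens), read by FLIPR, with a stated time of 1 h (on this read-out higher numbers stand for weaker inhibition and lower numbers for stronger inhibition), compound 1 `CN1CCc2nc(C#Cc3ccccc3)sc2C1` gives > 10000 nM, which is a limit of the assay rather than a number. Compound 2 `CN1CCc2nc(C#Cc3cccc(F)c3)sc2C1` gives > 10000 nM in this assay, again a limit. The step that the two limits leave unreadable from compound 1 to compound 2 therefore cannot be read. Going by the values given here, compound 3 `O=C(C1CCC1)N1CCc2nc(C#Cc3ccccc3)sc2C1` gives 370 nM in this assay and is the only compound here with a measured number. The other two values stop at the limit (the limit of > 10000 nM in this assay, at which 2 of the 3 values shown sit). Among the compounds with values here, the step of an at least 27-fold lower number from compound 1 to compound 3 (1.43 log units; beyond the scatter) is the one measured change with a readable size, and it shows that an amide on the ring nitrogen in place of a methyl group goes together with much stronger inhibition.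

Compound 4 `O=C(CC1CCOCC1)N1CCc2nc(C#Cc3ccccc3)sc2C1` has not been measured. It differs from compound 3 only at the carbonyl carbon: (oxan-4-yl)methyl in place of cyclobutyl on a carbonyl carbon. Within the data shown here, the amide itself stays, so the large step seen between compound 1 and compound 3 is not undone, but no measured step compares two different groups on that carbonyl carbon. The expected step is therefore a 1.4-fold higher number from compound 3 to compound 4 (0.13 log units; within the scatter), a change kept within the usual scatter. Compound 4 is expected to give about 500 nM in this assay, estimated between 150 nM and 2000 nM.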

Compound 4, half-maximal inhibitory concentration: > 10000 nM
Compound 4: no number, only a limit; the forecaster's own chance of this, stated with the estimate: 10%; middle value at least 20-fold (1.30 log units) away from the limit.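

Keeping the amide on the ring nitrogen is not enough to keep the inhibition, since the group on the carbonyl carbon also counts: in this assay, (oxan-4-yl)methyl in place of cyclobutyl gives an at least 27-fold higher number from compound 3 to compound 4 (1.43 log units; beyond the scatter). The value of compound 4, > 10000 nM, is a limit of the assay and not a number. Compound 3 now stands alone with a readable number, while compound 4, although it is an amide, sits at the same limit as the two methyl compounds, compound 1 and compound 2: the limit of > 10000 nM in this assay, at which 3 of the 4 values shown sit.

This single change alters several things at once, replacing the four-membered carbon ring with a six-membered ring, bringing in a ring oxygen and adding a methyl link to the carbonyl carbon, so the compounds shown cannot tell which of these goes with the drop in inhibition. Cyclohexylmethyl, which has no ring oxygen, and oxan-4-yl, which has no methyl link, would each pull one of these changes apart from the others, and neither is among the compounds shown.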